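From trifluoromethoxy to hydroxy in a growth-inhibition series

This account rests on a few compounds, and the source may have more. Where it says the series, first, only, none or still open, it means among the compounds named here.

Of the compounds shown here, three sharing one core have been measured in a functional assay on A2780 cells (Homo sapiens) for inhibition, read by sulforhodamine B assay; a higher number here means a weaker inhibitor of growth, a lower number a stronger inhibitor of growth. Compound 1 `Cc1ccc2[nH]c(-c3ccc(-c4ccc(-c5ccc(N(C)C)cc5)cc4)cc3)nc2c1`, which carries dimethylamino, gives 2210 nM. Compound 2 `Cc1ccc2[nH]c(-c3ccc(-c4ccc(-c5ccc(C(F)(F)F)cc5)cc4)cc3)nc2c1`, which carries trifluoromethyl, gives 12300 nM, and compound 3 `Cc1ccc2[nH]c(-c3ccc(-c4ccc(-c5ccc(OC(F)(F)F)cc5)cc4)cc3)nc2c1`, which carries trifluoromethoxy, gives 12300 nM. Compound 3 thus stands level with compound 2, and the two share the highest number of the set.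

Compound 4 `Cc1ccc2[nH]c(-c3ccc(-c4ccc(-c5ccc(O)cc5)cc4)cc3)nc2c1` follows from compound 3 by one change, hydrogen in place of trifluoromethyl on an oxygen on an aromatic ring, so that trifluoromethoxy becomes hydroxy. Among the measured compounds shown here, no hydroxy compound has been measured, so the evidence is indirect. Exchanging the two groups that carry fluorine made no difference, as no change at the digits printed from compound 2 to compound 3 (within the scatter) shows. Each of them differs from dimethylamino by a modest step beyond the scatter, as a 5.6-fold higher number from compound 1 to compound 2 (0.75 log units; beyond the scatter) and a 5.6-fold higher number from compound 1 to compound 3 (0.75 log units; beyond the scatter) show. Hydroxy, like the dimethylamino of compound 1 at 2210 nM, carries no fluorine, which is a thin basis for expecting a move in that direction. The expected change is a modest one towards a lower number, a 2.7-fold lower number from compound 3 to compound 4 (0.44 log units; beyond the scatter). For compound 4 the estimate is 4500 nM, with an expected range of 1500 nM to 13000 nM.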

Compound 4, concentration for 50% growth inhibition: 31200 nM
Beside the measured number, compound 4's estimate is 6.9-fold (0.84 log units) below it; the whole stated range lies below it.
By their numbers in this assay, from the lowest: compound 1; then compounds 2 and 3 (each within the scatter of the next); then compound 4.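

In this assay, taking trifluoromethyl off the oxygen on the aromatic ring leaves the hydroxy compound as the weakest inhibitor of growth of the four, with a 2.5-fold higher number from compound 3 to compound 4 (0.40 log units; beyond the scatter), and the comparison with the other fluorinated group runs the same way, with a 2.5-fold higher number from compound 2 to compound 4 (0.40 log units; beyond the scatter). The absence of fluorine therefore does not by itself lower the number at this position: the two compounds without fluorine stand at opposite ends of the set, with a 14-fold higher number from compound 1 to compound 4 (1.15 log units; beyond the scatter), the largest step seen so far, and the two fluorinated groups lie between them. Nothing available here bears on why hydroxy and dimethylamino part so widely at this position.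

The compounds shown leave open where a methoxy group, which would keep the oxygen and put a methyl on it, or a primary amine would fall at this place, and so whether the low number of compound 1 extends to amines more generally or belongs to dimethylamino alone. They also leave open whether a carboxylic acid would push the number higher still, and whether these steps would hold on a core other than the shared one.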